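This account rests on a few compounds, and the source may have more. Where it says the series, first, only, none or still open, it means among the compounds named here.

The measured compounds and their numbers in an assay on liver for binding affinity to Alpha-1A adrenergic receptor (Homo sapiens), using microsomes; on this read-out higher numbers stand for weaker inhibition and lower numbers for stronger inhibition:

compound 1, `COC(=O)C1=C(C)NC(=O)N(C(=O)NCCCN2CCN(c3ccccc3OC)CC2)C1c1ccc(F)c(F)c1`: 0.1 nM
compound 2, `COC(=O)C1=C(C)NC(=O)N(C(=O)NCCCN2CCN(c3ccccc3O)CC2)C1c1ccc(F)c(F)c1`: 0.6 nM
compound 3, `COC(=O)C1=C(C)NC(=O)N(C(=O)NCCCN2CCN(c3ccc(Cl)cc3)CC2)C1c1ccc(F)c(F)c1`: 0.8 nM

Compound 3 gives the highest of the three numbers in this assay. Its nearest neighbour is compound 2, and that gap, a 1.3-fold higher number from compound 2 to compound 3 (0.12 log units; within the scatter), lies within the scatter, so the two cannot be set in order. The furthest is compound 1, from which an 8.0-fold higher number from compound 1 to compound 3 (0.90 log units; beyond the scatter) is the largest step in the set.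

Compound 4, `CCOc1ccccc1N1CCN(CCCNC(=O)N2C(=O)NC(C)=C(C(=O)OC)C2c2ccc(F)c(F)c2)CC1`, is not yet measured. It differs from compound 3 in one place: 2-ethoxyphenyl in place of 4-chlorophenyl on an amine nitrogen in a ring.

Within the data shown here, two measured steps bear on this change. The step of an 8.0-fold higher number from compound 1 to compound 3 (0.90 log units; beyond the scatter) shows that replacing 2-methoxyphenyl with 4-chlorophenyl gave a modest rise; the step of a 6.0-fold higher number from compound 1 to compound 2 (0.78 log units; beyond the scatter) shows that losing the methyl from the oxygen on that ring also gave a modest rise. Compound 4 carries a 2-ethoxyphenyl, which keeps an oxygen bearing an alkyl group on the ring, as compound 1 does. Compound 4 is therefore expected to move back toward the number of compound 1, with an estimated 4.0-fold lower number from compound 3 to compound 4 (0.60 log units; beyond the scatter), because an 8.0-fold higher number from compound 1 to compound 3 (0.90 log units; beyond the scatter) ran the other way.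

The estimate for compound 4 in this assay is 0.2 nM, with a range from 0.05 nM to 0.8 nM.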

Compound 4, inhibition constant: 0.1 nM
Estimate against measurement, compound 4: 2.0-fold (0.30 log units) above; the range from low to high includes it.
By their numbers in this assay, from the lowest: compounds 1 and 4 (each within the scatter of the next); then compounds 2 and 3 (each within the scatter of the next).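

In this assay, 2-ethoxyphenyl in place of 4-chlorophenyl on the amine nitrogen in a ring gives an 8.0-fold lower number from compound 3 to compound 4 (0.90 log units; beyond the scatter) and so shows, in a direct step on compound 3, that this position responds to the group it carries. The alkyl group on the ring oxygen can also grow from methyl to ethyl, since the step shows no change at the digits printed from compound 1 to compound 4 (within the scatter) and the two compounds cannot be set in order. Ethyl in place of hydrogen on that oxygen gives a 6.0-fold lower number from compound 2 to compound 4 (0.78 log units; beyond the scatter) in this assay, so a second alkyl group now stands apart from the free hydroxyl, and among these four compounds both of the alkoxy-bearing compounds give lower numbers than compound 2 and compound 3, with no compound going against this.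

The compounds shown leave open whether a propyl group, an isopropyl group or a longer chain on that oxygen would hold the number of compound 4, and whether a chlorine on the 2-position of the phenyl ring would behave as 4-chlorophenyl does. Nothing at hand gives a measured reason for any of these steps.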